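Two Limits and an Untested Third Compound

The source may hold more compounds than are shown below. What is called first, only, known or untested is meant among the compounds shown, and "the series" means these compounds.

Measured so far:
Compound 1 `Cc1ccc(N2CCN(S(=O)(=O)C[C@]34CC[C@H](CC3=O)C4(C)C)CC2)nc1` gives > 31600 nM in this read-out, a limit of the assay.
Compound 2 `CC1(C)[C@@H]2CC[C@@]1(CS(=O)(=O)N1CCN(c3ccc(C#N)cn3)CC1)C(=O)C2` gives > 31600 nM in this read-out, also a limit of the assay.

In a functional assay on CHO-K1 cells for antagonist activity at C-X-C chemokine receptor type 3 (Homo sapiens), read by FLIPR and calcium flux (on this read-out higher numbers stand for weaker inhibition and lower numbers for stronger inhibition), compound 2 stands at a limit rather than at a number, and the same holds for compound 1, so the step that the two limits leave unreadable from compound 1 to compound 2 cannot be read in size or direction. Compound 2 therefore sits at the limit of > 31600 nM in this assay, at which 2 of the 2 values shown sit, with no measured value placing it anywhere within the range the assay can resolve.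

Compound 3 `CC1(C)[C@@H]2CC[C@@]1(CS(=O)(=O)N1CCN(c3ncc(C(F)(F)F)cn3)CC1)C(=O)C2` carries the change (5-(trifluoromethyl)pyrimidin-2-yl in place of 5-cyanopyridin-2-yl on an amine nitrogen in a ring). Among the compounds with values here, no measured step bears directly on this change; the only step among the measured compounds is the one from compound 1 to compound 2, and it is unreadable. With both measured compounds at the limit and no readable step to lean on, compound 3 is expected to remain at or near that limit, so the step that the limit leaves unreadable from compound 2 to compound 3 is estimated to be none beyond the scatter. Compound 3 is accordingly estimated at 40000 nM, with a range from 8000 nM to 200000 nM.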

Compound 3, half-maximal inhibitory concentration: 316 nM
Beside the measured number, compound 3's estimate is 130-fold (2.10 log units) above it; measured number outside the range, below it.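

The earlier compounds shown here could not show whether the group on an amine nitrogen in a ring has any hold on this assay at all, since the step between them cannot be read, and compound 3 shows that it does. Putting 5-(trifluoromethyl)pyrimidin-2-yl in place of 5-cyanopyridin-2-yl gives an at least 100-fold lower number from compound 2 to compound 3 (2.00 log units; beyond the scatter) and putting it in place of 5-methylpyridin-2-yl gives an at least 100-fold lower number from compound 1 to compound 3 (2.00 log units; beyond the scatter) while the shared core stays the same, and both sizes are floors rather than exact gaps. Of the three compounds, only compound 3 has left the limit and given a number: the limit of > 31600 nM in this assay, at which 2 of the 3 values shown sit.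

The change swaps the ring and its substituent together, so the compounds shown leave open whether the second ring nitrogen, the trifluoromethyl group or only the two together carry the gain. They also leave open how a chlorine atom, a methoxy group or a longer fluoroalkyl chain would fare on the pyrimidine ring in place of trifluoromethyl, and whether a pyridine ring bearing trifluoromethyl would leave the limit as well.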